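This account rests on a few compounds, and the source may have more. Where it says the series, first, only, none or still open, it means among the compounds named here.

Among the three measured compounds, compound 1 `COc1ccc(F)cc1Nc1cc(NC(=O)Nc2c(Cl)cccc2Cl)ncn1` stands highest in a functional assay on NCI-H1581 cells (Homo sapiens) for inhibition, read by MTT assay, with a stated time of 48 h, tested at 10 uM (a higher number here means more inhibition at the concentration tested (going by the name of the read-out), a lower number less inhibition), giving 73.1%. Compound 2 `COc1cc(NC(=O)Nc2cc(Nc3ccc(C)c(C)c3)ncn2)cc(OC)c1` gives 20.1% in this assay, and compound 3 `COc1cc(NC(=O)Nc2cc(Nc3cccc(C(C)(C)C)c3)ncn2)cc(OC)c1` gives 35.1%, so that the step of a number 15 percentage points higher from compound 2 to compound 3 (beyond the scatter) shows a modest shift when the aryl group on the nitrogen on the aromatic ring is exchanged. Compound 4 `O=C(Nc1cc(Nc2ccc(F)c(Cl)c2)ncn1)Nc1c(Cl)cccc1Cl` differs from compound 1 at that same place: 3-chloro-4-fluorophenyl in place of 5-fluoro-2-methoxyphenyl on a nitrogen on an aromatic ring. Within the data shown here, because the only comparable step is a number 15 percentage points higher from compound 2 to compound 3 (beyond the scatter), a step of similar size is expected here, most likely downward, since no measured compound carries this new group. Compound 4 is therefore expected to give 60%, within 35% to 80%. The expected step is a number 13.1 percentage points lower from compound 1 to compound 4 (beyond the scatter).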

Compound 4, a percentage reported as inhibition, at one concentration (the size of the read-out at that concentration, not a potency): 67%
Compound 4: the middle estimate sits 7 percentage points below what was measured; the measured number falls inside the stated range.
By their numbers in this assay, from the lowest: compound 2; then compound 3; then compounds 4 and 1 (each within the scatter of the next).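

In this assay, 3-chloro-4-fluorophenyl in place of 5-fluoro-2-methoxyphenyl on a nitrogen on an aromatic ring gives a number 6.1 percentage points lower from compound 1 to compound 4 (within the scatter). At this position, then, two aryl groups with different substituents read alike on the shared core of compound 1 and compound 4, and the methoxy oxygen of compound 1 can be absent without a change beyond the scatter. Nothing at hand explains this result. The compounds shown leave open whether this position needs an aryl group at all, and how a piperidine or a simple butyl chain in its place would read.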